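A few compounds are considered here, and "the series" means these few. Any claim that something is new, unique, unknown or untested is made for them only; others in the source may bear on it.

Among the compounds with values here, compound 1 `C(=C/c1ncnc2c1ncn2C1CCOCC1)\c1ccccc1` gives 66% in a functional assay on K562 cells (Homo sapiens) for inhibition, read by thymidine incorporation, with a stated time of 48 h, tested at 10 ug/mL (on this read-out lower numbers stand for less inhibition and higher numbers for more inhibition at the one concentration tested (going by the name of the read-out)), the lower of the two numbers measured so far. Within the data shown here, its one measured neighbour is compound 2 `C(=C/c1ncnc2c1ncn2Cc1ccccc1)\c1ccccc1`, in which benzyl replaces oxan-4-yl on the aromatic nitrogen. In this assay compound 2 gives 93%. The step of a number 27 percentage points higher from compound 1 to compound 2 (beyond the scatter) concerns the group on the aromatic nitrogen, not the phenyl ring.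

Compound 3 `COc1ccc(/C=C/c2ncnc3c2ncn3C2CCOCC2)cc1` differs from compound 1 by methoxy in place of hydrogen on an aromatic carbon. Among the measured compounds shown here, no measured step touches this ring, so nothing points to a shift in either direction, and none beyond the scatter is expected. Compound 3 is therefore expected to give about 65%, within 40% to 85%. For compound 3 this expectation amounts to a number 1 percentage points lower from compound 1 to compound 3 (within the scatter).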

Compound 3, a percentage reported as inhibition, at one concentration (the size of the read-out at that concentration, not a potency): 58%
Compound 3: middle estimate off by 7 percentage points, on the high side; measured number inside the range.
By their numbers in this assay, from the lowest: compounds 3 and 1 (each within the scatter of the next); then compound 2.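

In this assay, within the data shown here, the step of a number 8 percentage points lower from compound 1 to compound 3 (within the scatter) gives the first reading on the phenyl ring, which the earlier pair left untouched. With oxan-4-yl on the aromatic nitrogen, methoxy para to a large group therefore makes no change beyond the scatter, unlike the step between the nitrogen groups. No measurement at hand offers an explanation for this result. As far as these compounds go, whether an amine or a carboxylic acid in the same place would also stay within the scatter remains open. So does whether methoxy would behave the same way with benzyl on the nitrogen, as in compound 2.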